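Allyl to 2-methoxyethyl on the aromatic amine

The source may hold more compounds than are shown below. What is called first, only, known or untested is meant among the compounds shown, and "the series" means these compounds.

Values in a functional assay (Nicotiana tabacum); on this read-out higher numbers stand for weaker inhibition and lower numbers for stronger inhibition:
- compound 1 `CCCCCCNc1nc(SC)nc2ncccc12`: 3330 nM
- compound 2 `CSc1nc(NC2CCC2)c2cccnc2n1`: 720 nM
- compound 3 `C=CCNc1nc(SC)nc2ncccc12`: 400 nM

Compound 3 stands at the low end of this assay together with compound 2, with a 1.8-fold lower number from compound 2 to compound 3 (0.26 log units; within the scatter). The gap to compound 1 is clearer, with an 8.3-fold lower number from compound 1 to compound 3 (0.92 log units; beyond the scatter).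

The next compound is compound 4 `COCCNc1nc(SC)nc2ncccc12`, which carries 2-methoxyethyl in place of allyl. This is methoxymethyl in place of vinyl on a saturated chain carbon bound to a nitrogen on an aromatic ring.

Within the data shown here, only the steps at this same nitrogen bear on the change. Starting from hexyl, a 4.6-fold lower number from compound 1 to compound 2 (0.67 log units; beyond the scatter) and an 8.3-fold lower number from compound 1 to compound 3 (0.92 log units; beyond the scatter) are both modest. Among the measured compounds shown here, no measured compound carries methoxymethyl in this place, so the data give no direct reading. The only open chain other than allyl, hexyl in compound 1, stands higher, so a modest rise is expected, near the edge of the scatter. The expected step is a 2.0-fold higher number from compound 3 to compound 4 (0.30 log units; within the scatter). For compound 4 the estimate is 800 nM, with an expected range of 300 nM to 2300 nM.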

Compound 4, half-maximal inhibitory concentration: 2530 nM
Compound 4: the middle estimate sits 3.2-fold (0.50 log units) below what was measured, outside the stated range (above it).
By their numbers in this assay, from the lowest: compounds 3 and 2 (each within the scatter of the next); then compounds 4 and 1 (each within the scatter of the next).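

In this assay the change from allyl to 2-methoxyethyl is not a small edit at this nitrogen (a 6.3-fold higher number from compound 3 to compound 4 (0.80 log units; beyond the scatter)), and compound 4 also separates from the cyclobutyl compound (a 3.5-fold higher number from compound 2 to compound 4 (0.55 log units; beyond the scatter)). Compound 4 cannot be told apart from the hexyl compound (a 1.3-fold lower number from compound 1 to compound 4 (0.12 log units; within the scatter)), so methoxy in place of butyl at the end of the chain makes no readable difference, and the four compounds fall into two groups: compounds 2 and 3, and compounds 1 and 4. No available measurement accounts for the rise from allyl.

From the compounds shown here alone, whether a 2-hydroxyethyl, 2-aminoethyl or 3-methoxypropyl group on this nitrogen would sit with compound 3 or with compound 4 remains open. Going by these compounds, all four compounds share the same core, so it is also open whether these steps hold with an amine in place of the methylthio group.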